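The source may hold more compounds than are shown below. What is called first, only, known or untested is meant among the compounds shown, and "the series" means these compounds.

Measured compounds and their numbers:
compound 1, `CC1CC(=O)c2s/c(=N/c3ccccc3)oc2C1`, gives 2630 nM in a functional assay on PC-3 cells (Homo sapiens) for antiproliferative activity, read by sulforhodamine B assay; a higher number here means a weaker inhibitor of growth, a lower number a stronger inhibitor of growth
compound 2, `CC(C)C1CC(=O)c2s/c(=N/c3ccccc3)oc2C1`, gives 2190 nM in this assay
compound 3, `CC1(C)CC(=O)c2s/c(=N/C3CCCCC3)oc2C1`, gives 12700 nM in this assay

Compound 2 holds the lowest of the three numbers in this assay, but its separation from compound 1, a 1.2-fold lower number from compound 1 to compound 2 (0.08 log units; within the scatter), lies within the scatter, so the two cannot be ordered. Compound 3 stands furthest from compound 2, with a clearly higher number.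

Compound 4, `CC(C)C1CC(=O)c2s/c(=N/C3CCCCC3)oc2C1`, has not yet been measured. It differs from compound 2 by cyclohexyl in place of phenyl on a double-bonded nitrogen. Among the compounds with values here, no measured step isolates this change. Within the data shown here, the one measured step, a 1.2-fold lower number from compound 1 to compound 2 (0.08 log units; within the scatter), concerns a different position and is within the scatter. Compound 3 carries cyclohexyl on the double-bonded nitrogen but also differs from compound 2 on the saturated ring, so the values of compound 2 and compound 3 show a higher number alongside cyclohexyl without separating the two changes.

Taking that comparison as a rough guide, compound 4 is expected to give a higher number in this assay than compound 2, a step of a 3.7-fold higher number from compound 2 to compound 4 (0.56 log units; beyond the scatter). The estimate for compound 4 is 8000 nM, with an expected range from 3000 nM to 25000 nM.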

Compound 4, concentration for 50% growth inhibition: 5160 nM
Compound 4: middle estimate off by 1.6-fold (0.19 log units), on the high side; low and high end bracket the measured number.
By their numbers in this assay, from the lowest: compounds 2, 1 and 4 (each within the scatter of the next, the first and the last beyond it); then compound 3.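

With the isopropyl group on the saturated ring held constant, the swap of phenyl for cyclohexyl on the double-bonded nitrogen can now be read on its own in this assay: a 2.4-fold higher number from compound 2 to compound 4 (0.37 log units; beyond the scatter), a modest step, but one beyond the scatter. Within the data shown here, until now cyclohexyl had appeared only alongside a different substitution on the saturated ring, so this pair is the first to show that this position responds to the change by itself, with an aromatic ring giving way to a non-aromatic ring of the same carbon count and no hydrogen-bond donors or acceptors on either side. Nothing available explains why the number rises with this change.

This single pair cannot show whether the swap would produce a similar step with methyl on the saturated ring, since the change is seen only once among the compounds shown. Also open, as far as these compounds go, is how a pyridyl ring, a benzyl group or a longer open carbon chain on the double-bonded nitrogen would compare with phenyl and cyclohexyl.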